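The source may hold more compounds than are shown below. What is called first, only, known or untested is meant among the compounds shown, and "the series" means these compounds.

Measured so far:
compound 1, `N[C@@H](COP(=O)(O)OCCCOC(=O)CCc1ccccc1OCCCCOc1ccccc1)C(=O)O` — 0.033
compound 2, `N[C@@H](COP(=O)(O)OCCCOC(=O)CCc1ccccc1OCCCCCCOc1ccccc1)C(=O)O` — 0.071
compound 3, `Cc1ccccc1Oc1cccc(COc2ccccc2CCC(=O)OCCCOP(=O)(O)OC[C@H](N)C(=O)O)c1` — 0.28

In an assay on cells for activation of probable G-protein coupled receptor 34 (Mus musculus), with a stated time of 1 h (on this read-out lower numbers stand for smaller maximal responses and higher numbers for larger maximal responses), compound 3 stands highest of the three, with compound 2 nearest and compound 1 furthest, both gaps beyond the scatter. Compound 4, `N[C@@H](COP(=O)(O)OCCCOC(=O)CCc1ccccc1OCc1cccc(Oc2ccc(Cl)cc2)c1)C(=O)O`, differs from compound 3 by 4-chlorophenyl in place of 2-methylphenyl on an oxygen on an aromatic ring. Within the data shown here, no measured step touches this part of the structure. Among the measured compounds shown here, the only measured step, a number 0.038 higher from compound 1 to compound 2 (within the scatter), lies within the scatter and concerns a different part of the molecule, so it offers no guide to the direction here. With nothing pointing either way, the account expects a step of a number 0.030 lower from compound 3 to compound 4 (within the scatter), that is no change beyond the scatter. The estimate for compound 4 in this assay is therefore 0.25, within 0.12 to 0.4.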

Compound 4, intrinsic activity: the largest response reached, as a fraction of the reference agonist's: 0.76
The estimate for compound 4 lay 0.51 below the measured number; measured number outside the range, above it.
By their numbers in this assay, from the lowest: compounds 1 and 2 (each within the scatter of the next); then compound 3; then compound 4.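

In this assay the group on this oxygen on an aromatic ring proves to matter greatly: 4-chlorophenyl in place of 2-methylphenyl gives a number 0.48 higher from compound 3 to compound 4 (beyond the scatter) even though both groups have the same heavy-atom count and a single six-membered aromatic ring. No measurement available here explains this step. On these data alone, how 2-chlorophenyl, 4-methylphenyl or unsubstituted phenyl would stand on that oxygen remains open, and with it whether the step follows the chlorine, its place on the ring or the loss of the methyl.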